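Series notes: hydrogen for methoxy on the fused ring

The compounds below may be only part of what the source reports. "The series", "measured", "known", "first", "only" and "open" are said of these compounds alone.

Measured so far:
compound 1, `COc1cccc2c1OCN(c1ccc3oc(-c4ccccc4)cc(=O)c3c1)C2` — 17000 nM
compound 2, `Cc1cc(C)c2c(c1)CN(c1ccc3c(=O)cc(-c4ccccc4)oc3c1)CO2` — 61900 nM

In a functional assay on MCF7 cells (Homo sapiens) for inhibition, read by MTT assay, with a stated time of 48 h (on this read-out higher numbers stand for weaker inhibition and lower numbers for stronger inhibition), compound 1 gives 17000 nM and holds the lowest of the two numbers; compound 2 gives 61900 nM, a higher number beyond the usual scatter. Compound 3 is `O=c1cc(-c2ccccc2)oc2ccc(N3COc4ccccc4C3)cc12`. It differs from compound 1 by hydrogen in place of methoxy on an aromatic carbon. For the measured compounds named here, no pair of measured compounds isolates this change, and compound 2 alters the same fused ring in a different way, so no direction is established. A step of a 1.5-fold higher number from compound 1 to compound 3 (0.17 log units; within the scatter) is expected, within the scatter, if anything toward a higher number. For compound 3 the estimate is 25000 nM, with a range of 8000 nM to 75000 nM.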

Compound 3, half-maximal inhibitory concentration: 27500 nM
The estimate for compound 3 lay 1.1-fold (0.04 log units) below the measured number, within the range that was stated.
By their numbers in this assay, from the lowest: compounds 1 and 3 (each within the scatter of the next); then compound 2.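

Hydrogen in place of methoxy on an aromatic carbon gives, in this assay, a 1.6-fold higher number from compound 1 to compound 3 (0.21 log units; within the scatter), the first step in the series that isolates a single place. At this level of inhibition, the methoxy group is therefore not needed: this one pair shows no difference beyond the scatter. No measured evidence bears on the reason for this result. Still open, from the compounds shown here alone, is whether any other group on this aromatic carbon, such as an amine, a carboxylic acid or a longer chain, would move the number beyond the scatter.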